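The compounds below may be only part of what the source reports. "The series", "measured", "known", "first", "only" and "open" are said of these compounds alone.

Measured compounds:
compound 1 `CC(C)(C)OC(=O)NCCC[C@@H]1N=C2C[C@@H]3C[C@@H](C3(C)C)[C@]2(C)OC1=O`: > 1200000 nM
compound 2 `CC(C)(C)OC(=O)CC[C@H]1N=C2C[C@H]3C[C@H](C3(C)C)[C@@]2(C)OC1=O`: > 1200000 nM
compound 3 `CC1(C)N=C2C[C@H]3C[C@H](C3(C)C)[C@@]2(C)OC1=O`: > 2000000 nM

In an ADME assay on NIH3T3 cells (Mus musculus) for antiproliferative activity, read by sulforhodamine B assay, with a stated time of 48 h (on this read-out higher numbers stand for weaker inhibition and lower numbers for stronger inhibition), compound 1 gives > 1200000 nM, which is a limit of the assay and not a number. Compound 2 also sits at a limit in this assay, > 1200000 nM. Compound 3 sits at a different limit in this assay, > 2000000 nM. None of the three therefore yields a measurable value: two share the limit of > 1200000 nM in this assay, at which 2 of the 3 values shown sit, and one sits at the limit of > 2000000 nM in this assay, at which 1 of the 3 values shown sits. Compound 1 thus stands at a limit, and its place among the three cannot be ordered.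

Compound 4 `CC(C)(C)OC(=O)NCCCC[C@@H]1N=C2C[C@@H]3C[C@@H](C3(C)C)[C@]2(C)OC1=O` has not yet been measured in this assay. It differs from compound 1 by ((tert-butoxycarbonyl)amino)methyl in place of (tert-butoxycarbonyl)amino on a saturated chain carbon, three bonds along the chain from a saturated ring carbon. Among the measured compounds shown here, no step between measured compounds is available, so nothing measured bears on what this change does here. Compound 1 gives only a limit in this assay, > 1200000 nM. The expected step is none beyond the scatter: a number no higher from compound 1 to compound 4 (the limit leaves the size open). For compound 4 the estimate in this assay is 1200000 nM, with a range from 600000 nM to 2400000 nM, and the assay is expected most likely to report only a limit again.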

Compound 4, half-maximal inhibitory concentration: > 800000 nM
Compound 4: a limit, no number; the forecaster's own chance of this, stated with the estimate: 85%; the middle value is on the limit's open side.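

Compound 1 and compound 4 both give only limits, not numbers, in this assay, so the step between them cannot be read. The compounds shown leave open whether ((tert-butoxycarbonyl)amino)methyl in place of (tert-butoxycarbonyl)amino changes antiproliferative activity at all, as none yields a measurable value.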